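The compounds below may be only part of what the source reports. "The series", "measured", "known", "first", "only" and "open" are said of these compounds alone.

Measured compounds in an ADME assay on L929 cells (Mus musculus) for cytotoxicity, read by resazurin assay, with a stated time of 72 h; a lower number here means a stronger inhibitor, a higher number a weaker inhibitor:

Compound 1 `Cc1ccc(C(=O)/C=C/c2ccc3c(c2)B(O)OC3)cc1`: compound 1 gives > 10 ug/mL, a limit of the assay.
Compound 2 `O=C(/C=C/c1ccc2c(c1)B(O)OC2)c1cccc(F)c1`: compound 2 gives > 10 ug/mL, a limit of the assay.
Compound 3 `O=C(/C=C/c1ccc2c(c1)B(O)OC2)c1ccco1`: compound 3 gives > 10 ug/mL, a limit of the assay.

Compound 2 stands at the limit of > 10 ug/mL in this assay, at which 3 of the 3 values shown sit, so it has no number of its own, only a limit. The step to be followed runs to compound 4 `COc1cccc(C(=O)/C=C/c2ccc3c(c2)B(O)OC3)c1`: methoxy in place of fluoro on an aromatic carbon. The measured steps that bear on a change at the carbonyl-borne ring are a step that the two limits leave unreadable from compound 1 to compound 2, a step that the two limits leave unreadable from compound 1 to compound 3 and a step that the two limits leave unreadable from compound 2 to compound 3; none of them yields a readable size, as each end sits at the same limit. No direction can be taken from them, and no step beyond the scatter is indicated. Compound 4 is therefore expected to remain near the limit, estimated at 15 ug/mL with a range from 5 ug/mL to 40 ug/mL, the expected step being a step that the limit leaves unreadable from compound 2 to compound 4.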

Compound 4, half-maximal inhibitory concentration: > 10 ug/mL
Compound 4: no number, only a limit; the forecaster's own chance of this, stated with the estimate: 80%; the middle value is on the limit's open side.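

No step can be read from compound 2 to compound 4 in this assay, since both sit at the same limit: the limit of > 10 ug/mL in this assay, at which 4 of the 4 values shown sit.

The compounds shown leave open where any of their actual values lies, and whether a change at the carbonyl-borne ring shifts it.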